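The source may report more compounds than this note shows. Statements on the series, on what has been measured and on what is new or still open speak of the compounds shown alone.

Three compounds of one shared core were measured in an ADME assay on Vero cells (Chlorocebus sabaeus) for cytotoxicity, read by neutral red uptake, tested at 394 ug/mL; on this read-out lower numbers stand for a stronger effect and higher numbers for a weaker effect at the one concentration tested:

- compound 1, `COc1ccc(C2SCC(=O)N2CCN2CCCCC2)cc1`, giving 73%
- compound 2, `O=C1CSC(c2ccc([N+](=O)[O-])cc2)N1CCN1CCCCC1`, giving 66%
- compound 3, `Cc1ccc(C2SCC(=O)N2CCN2CCCCC2)cc1`, giving 51%

On these numbers compound 3 stands lowest of the three. Its nearest neighbour is compound 2, and the step between them, a number 15 percentage points lower from compound 2 to compound 3 (beyond the scatter), lies beyond the scatter. The step from compound 1, a number 22 percentage points lower from compound 1 to compound 3 (beyond the scatter), is larger still. The step of a number 7 percentage points lower from compound 1 to compound 2 (within the scatter) stays within the scatter, so the three differ in how the group on the aromatic ring affects the read-out, not in the core.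

Compound 4, `O=C1CSC(c2ccc(Cl)cc2)N1CCN1CCCCC1`, differs from compound 3 in one place: chloro in place of methyl on an aromatic carbon. Within the data shown here, no measured step exchanges a methyl for a chloro, so the three steps above bear on it only loosely, by showing that a single exchange of the group in this position has moved the number by anything from within the scatter up to a modest amount. Among the measured compounds shown here, with no direct precedent, the expected step of a number 4 percentage points higher from compound 3 to compound 4 (within the scatter) is taken as small and uncertain in direction, leaning slightly back toward the values of compounds 1 and 2.

Compound 4 is therefore estimated to give 55%, within a range from 38% to 72%.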

Compound 4, a percentage reported as activity, at one concentration (the size of the read-out at that concentration, not a potency): 28%
Compound 4: the middle estimate sits 27 percentage points above what was measured, and the stated range ends above it.
By their numbers in this assay, from the lowest: compound 4; then compound 3; then compounds 2 and 1 (each within the scatter of the next).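

In this assay, among these compounds, chloro gives the lowest number of the four compounds and so the strongest effect at the one concentration tested (the steps read a number 23 percentage points lower from compound 3 to compound 4 (beyond the scatter) and a number 38 percentage points lower from compound 2 to compound 4 (beyond the scatter) and a number 45 percentage points lower from compound 1 to compound 4 (beyond the scatter)), and the two large steps show that a single exchange at this position on the aromatic ring can move the read-out much further than the modest steps seen among the earlier compounds. The exchange of methyl for chloro is also a small one on paper: one heavy atom replaces one heavy atom, and no ring, hydrogen-bond donor, hydrogen-bond acceptor or net charge enters or leaves, yet the step lies beyond the scatter. Nothing on hand bears on why chloro stands apart from the other three groups.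

With only four groups shown at this position, it remains open whether the low number belongs to chloro alone or also appears with fluoro or bromo, and what an amine or a carboxylic acid would give there. From the compounds shown here alone, it is also open whether chloro would keep its effect if the chain on the shared core were longer.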